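A few compounds are considered here, and "the series" means these few. Any claim that something is new, unique, unknown or untested is made for them only; others in the source may bear on it.

Compound 3 `CC(=O)c1ccc2c(c1)C1CNCC2C1` gives the lowest number of the three measured compounds in an assay on HEK293 cells for binding affinity to Neuronal acetylcholine receptor; alpha4/beta2 (Homo sapiens) (on this read-out lower numbers stand for stronger inhibition and higher numbers for weaker inhibition), at 0.17 nM. Compound 1 `Cc1ccc2c(c1)C1CNCC2C1` gives 1.6 nM in this assay, and compound 2 `Oc1cccc2c1C1CNCC2C1` gives 1700 nM. Among the compounds with values here, the one measured step at the same place is a 9.4-fold lower number from compound 1 to compound 3 (0.97 log units; beyond the scatter). Compound 4 `FC(F)(F)c1ccc2c(c1)C1CNCC2C1` differs from compound 3 in one place: trifluoromethyl in place of acetyl on an aromatic carbon. Within the data shown here, no measured step covers this exchange directly, and compound 2 carries a different group at a different place, so only the step between compound 1 and compound 3 bears on it. Because the step of a 9.4-fold lower number from compound 1 to compound 3 (0.97 log units; beyond the scatter) ties the acetyl group to the lowest number, removing it is expected to raise the number by a modest amount. Compound 4 is therefore estimated at 1.5 nM, between 0.3 nM and 8 nM, a step of an 8.8-fold higher number from compound 3 to compound 4 (0.95 log units; beyond the scatter).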

Compound 4, inhibition constant: 0.33 nM
Estimate against measurement, compound 4: 4.5-fold (0.66 log units) above; measured number inside the range.
By their numbers in this assay, from the lowest: compounds 3 and 4 (each within the scatter of the next); then compound 1; then compound 2.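

At this aromatic carbon, the carbonyl of acetyl proves not to be required for a low number: the exchange for trifluoromethyl gives a 1.9-fold higher number from compound 3 to compound 4 (0.29 log units; within the scatter). Trifluoromethyl also keeps an advantage over methyl at the same place, with a 4.8-fold lower number from compound 1 to compound 4 (0.69 log units; beyond the scatter), so two different groups now give lower numbers than methyl. Nothing shown here explains why acetyl and trifluoromethyl fall so close together. The compounds shown leave open how an amine, a carboxylic acid or a longer chain would fare at this place.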